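This account rests on a few compounds, and the source may have more. Where it says the series, first, only, none or still open, it means among the compounds named here.

In a functional assay on A549 cells (Homo sapiens) for cytotoxicity, read by MTT assay (on this read-out lower numbers stand for stronger inhibition and higher numbers for weaker inhibition), compound 1 `COC(=O)C[C@@H]1C[C@@H](O)[C@H](C)[C@H](c2ccccc2)N1` gives 8500 nM. Compound 2 `COC(=O)C[C@H]1C[C@H](O)[C@@H](C)[C@@H](c2ccc(OC)cc2)N1` gives 5400 nM in this assay; the difference between the two cores is not broken down here, and the two values lie within the usual scatter of each other. Compound 3 `C[C@H]1[C@H](O)C[C@@H](CCO)N[C@H]1c1ccccc1` carries hydroxymethyl in place of methoxycarbonyl on a saturated chain carbon bound to a saturated ring carbon and gives 31200 nM in this assay, so that this change produced a 3.7-fold higher number from compound 1 to compound 3 (0.56 log units; beyond the scatter). Compound 4 `COc1ccc([C@H]2N[C@@H](CCO)C[C@H](O)[C@H]2C)cc1` is not yet measured and carries hydroxymethyl in place of methoxycarbonyl on a saturated chain carbon bound to a saturated ring carbon, the same change, made on the core of compound 2. In this assay the step expected for compound 4 is a 3.7-fold higher number from compound 2 to compound 4 (0.57 log units; beyond the scatter), resting on the single measured case a 3.7-fold higher number from compound 1 to compound 3 (0.56 log units; beyond the scatter) and carrying the uncertainty of one example. Compound 4 is therefore estimated at about 20000 nM in this assay, expected between 9000 nM and 45000 nM.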

Compound 4, half-maximal inhibitory concentration: 17600 nM
Beside the measured number, compound 4's estimate is 1.1-fold (0.06 log units) above it, and the stated range covers the measured number.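

On the core of compound 2, hydroxymethyl in place of methoxycarbonyl gives a 3.3-fold higher number from compound 2 to compound 4 (0.51 log units; beyond the scatter) in this assay. The size of the step carries over between the two cores shown: the same change on two cores in this assay, a 3.7-fold higher number (0.56 log units; beyond the scatter) from compound 1 to compound 3 and a 3.3-fold higher number (0.51 log units; beyond the scatter) from compound 2 to compound 4, 1.1-fold (0.05 log units) apart, within the scatter of two such steps. This covers two cores and this one change only; it does not show that the step would hold on other cores, and it gives no explanation for the higher numbers.

Still open, from the compounds shown here alone, is how a carboxylic acid, an amide or an amine would read at this place on a saturated chain carbon bound to a saturated ring carbon. Also open, going by these compounds, is whether a longer chain ending in hydroxyl would follow the same step in this assay.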